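The source may hold more compounds than are shown below. What is called first, only, known or untested is meant among the compounds shown, and "the series" means these compounds.

Compound 1 `O=C1NCCN1c1ccc(S(=O)(=O)Nc2ccc(I)cc2)cc1`: 260 nM
Compound 2 `O=C1NCCN1c1ccc(S(=O)(=O)Nc2ccc(Cl)cc2)cc1`: 90 nM

In a functional assay on M21 cells (Homo sapiens) for antiproliferative activity, read by sulforhodamine B assay, with a stated time of 48 h (on this read-out higher numbers stand for weaker inhibition and lower numbers for stronger inhibition), compound 2 at 90 nM holds the lower of the two numbers. Compound 3 `Cc1ccccc1NS(=O)(=O)c1ccc(N2CCNC2=O)cc1` has 2-methylphenyl in place of 4-chlorophenyl on a sulfonamide nitrogen. Going by the values given here, the one measured step (a 2.9-fold lower number from compound 1 to compound 2 (0.46 log units; beyond the scatter)) is modest and beyond the scatter, and it is chloro in place of iodo. Among the compounds with values here, no measured compound carries 2-methylphenyl, so that step is only a loose guide to size. A modest step toward a higher number is expected (a 2.8-fold higher number from compound 2 to compound 3 (0.44 log units; beyond the scatter)). Compound 3 is estimated at 250 nM within an expected range (70 nM to 900 nM).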

Compound 3, half-maximal inhibitory concentration: 150 nM
Compound 3: middle estimate off by 1.7-fold (0.22 log units), on the high side, within the range that was stated.
By their numbers in this assay, from the lowest: compounds 2, 3 and 1 (each within the scatter of the next, the first and the last beyond it).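

In this assay, 2-methylphenyl on the sulfonamide nitrogen gives a 1.7-fold higher number from compound 2 to compound 3 (0.22 log units; within the scatter) and a 1.7-fold lower number from compound 1 to compound 3 (0.24 log units; within the scatter) and so cannot be separated from either halogen-bearing compound. Among these three compounds, a halogen on the ring at this position is therefore not required for a value in this range. No available data explain the result. Compound 3 changes both the substituent and its place on the ring, so these two changes remain unseparated. On these data alone, whether an amine or a carboxylic acid on this ring would be accepted remains open.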